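This account rests on a few compounds, and the source may have more. Where it says the series, first, only, none or still open, it means among the compounds named here.

Working notes on the series. Compound 1 `COc1ccc(C(=O)O[C@@H]2CO[C@H]3[C@@H]2OC[C@@H]3OC(=O)c2ccccc2OC(C)=O)cc1` and compound 2 `CC(=O)Oc1ccccc1C(=O)O[C@H]1CO[C@H]2[C@@H]1OC[C@H]2OC(=O)c1ccc(-c2ccccc2)cc1` share one core and differ by a phenyl in place of methoxy on an aromatic carbon. In an ADME assay on a cell-free system (plasma, Homo sapiens) for metabolic stability, with Plasma (Rattus norvegicus) as the target, read by HPLC, at pH 7.4 (on this read-out higher numbers stand for a longer-lived compound and lower numbers for a shorter-lived compound), compound 1 gives 0.0183 h. For compound 2 this assay reports only a limit of the assay, > 0.333 h. For the measured compounds named here, the single measured step, an at least 18-fold higher number from compound 1 to compound 2 (1.25 log units; beyond the scatter), rests on (the limit of > 0.333 h in this assay, at which 1 of the 2 values shown sits), so only a floor of its true size is known. Compound 2 thus stands at the upper edge of what has been recorded here, beyond the reach of the numbers.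

Compound 3 `CC(=O)Oc1ccccc1C(=O)O[C@H]1CO[C@H]2[C@@H]1OC[C@H]2OC(=O)CCO[N+](=O)[O-]` has not yet been measured in this assay. It differs from compound 2 by 2-(nitrooxy)ethyl in place of 4-phenylphenyl on a carbonyl carbon. Going by the values given here, only the step from compound 1 to compound 2 bears on it, and only loosely: that step was a phenyl in place of methoxy on an aromatic carbon, whereas the present change removes the whole 4-phenylphenyl in favour of 2-(nitrooxy)ethyl. A step downward is expected, an at least 3.3-fold lower number from compound 2 to compound 3 (0.52 log units; beyond the scatter). For compound 3 the estimate in this assay is 0.1 h, expected to lie between 0.02 h and 0.5 h.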

Compound 3, half-life: 0.0217 h
Compound 3: the middle estimate sits 4.6-fold (0.66 log units) above what was measured; low and high end bracket the measured number.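

Moving from 4-phenylphenyl to 2-(nitrooxy)ethyl on a carbonyl carbon whose other neighbour is an oxygen next to a carbonyl group gives an at least 15-fold lower number from compound 2 to compound 3 (1.18 log units; beyond the scatter), a large step whose true size is only a floor, as compound 2 is reported as a limit of the assay: the limit of > 0.333 h in this assay, at which 1 of the 3 values shown sits. The same place carrying 2-(nitrooxy)ethyl or 4-methoxyphenyl gives a 1.2-fold higher number from compound 1 to compound 3 (0.07 log units; within the scatter), so these two groups are not told apart in this assay, although one holds an aromatic ring and the other no ring. Among the three compounds, then, only the 4-phenylphenyl of compound 2 separates from the others at this place, and a single aromatic ring there, as in compound 1, does not bring the read-out towards that of compound 2.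

The compounds shown leave open whether a plain phenyl, a cyclohexyl or a longer alkyl chain on this carbonyl carbon would read with compound 2 or with compound 1 and compound 3. From the compounds shown here alone, how an amide in place of this ester would read in this assay also stays open.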